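Halogenated aryl swap on the imidazole nitrogen of compound 1

This account rests on a few compounds, and the source may have more. Where it says the series, first, only, none or still open, it means among the compounds named here.

Within the data shown here, compound 1 `Cc1cc2occ(-c3nc(-c4ccccc4)c(-c4ccccc4)n3-c3ccc(Cl)c(Cl)c3)c(=O)c2cc1Cl` is the only member of this small set with a number in an ADME assay on MCF-10A cells (Homo sapiens) for cytotoxicity, read by MTT assay, with a stated time of 72 h (a higher number here means a weaker inhibitor, a lower number a stronger inhibitor), where compound 1 gives 98000 nM. Of its two companions, compound 2 `Cc1cccc(-n2c(-c3coc4cc(C)c(Cl)cc4c3=O)nc(-c3ccccc3)c2-c2ccccc2)c1` shows "not determined" (no result reported) in this assay, and compound 3 `Cc1cc2occ(-c3nc(-c4ccccc4)c(-c4ccccc4)n3-c3ccccc3Cl)c(=O)c2cc1Cl` likewise shows "not determined" (no result reported) in this assay, so compound 1 stands alone as the reference point. Compound 4 `Cc1cc2occ(-c3nc(-c4ccccc4)c(-c4ccccc4)n3-c3ccc(Br)cc3)c(=O)c2cc1Cl` has not been tested yet. It differs from compound 1 by a single exchange on the aromatic nitrogen, (4-bromophenyl in place of 3,4-dichlorophenyl on an aromatic nitrogen), while the rest of the shared core is unchanged. With no second measured compound to define a step, the size of the change can only be estimated, and the shared core together with the small shift from one halogenated phenyl group to another gives no reason to expect movement beyond the scatter in either direction. Compound 4 is therefore expected to show a step of a 1.1-fold lower number from compound 1 to compound 4 (0.04 log units; within the scatter), and its value is estimated at 90000 nM, within a range from 40000 nM to 200000 nM.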

Compound 4, half-maximal inhibitory concentration: > 100000 nM
Compound 4 gave a limit, no number; the forecaster's own chance of this, stated with the estimate: 25%; at least 1.1-fold (0.04 log units) between middle value and limit.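

In this assay compound 4 gives > 100000 nM, which is a limit and not a number. The exchange of 3,4-dichlorophenyl for 4-bromophenyl on the aromatic nitrogen amounts to an at least 1.0-fold higher number from compound 1 to compound 4 (0.00 log units; that floor lies within the scatter), so this step is only a floor and sets no upper bound on the change. Among these compounds, what this adds to the single earlier number is a first reading of a second halogenated phenyl group at this position: with one chlorine pair replaced by a single bromine, the number in this assay did not come out lower.

From the compounds shown here alone, how far the true value of compound 4 lies past its limit remains open. So does whether an amine or a carboxylic acid on this phenyl ring, in place of the halogens, would bring a measurable number in this assay.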